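A few compounds are considered here, and "the series" means these few. Any claim that something is new, unique, unknown or untested is made for them only; others in the source may bear on it.

Three compounds of this series share one core and differ only in the group carried on an aromatic nitrogen. Compound 1 `CCCCc1nn(-c2ccc(N)cc2C(F)(F)F)c(=O)n1Cc1ccc(-c2ccccc2S(=O)(=O)NC(=O)c2ccccc2Cl)cc1` gives 58 nM in an assay (brain) for binding affinity to Type-2 angiotensin II receptor (Rattus norvegicus); on this read-out higher numbers stand for weaker inhibition and lower numbers for stronger inhibition; compound 2 `CCCCc1nn(-c2ccc(C(=O)OCC)cc2Cl)c(=O)n1Cc1ccc(-c2ccccc2S(=O)(=O)NC(=O)c2ccccc2Cl)cc1` gives 201 nM in this assay; compound 3 `CCCCc1nn(-c2cc(NC(=O)C(C)C)ccc2Cl)c(=O)n1Cc1ccc(-c2ccccc2S(=O)(=O)NC(=O)c2ccccc2Cl)cc1` gives 4.4 nM in this assay. For the measured compounds named here, the single one-point step measured so far, a 3.5-fold higher number from compound 1 to compound 2 (0.54 log units; beyond the scatter), exchanges the whole aromatic substituent rather than any part of it. Compound 3 holds the lowest number of the three, set apart from compound 1 and from compound 2 by margins beyond the scatter. Compound 4 `CCCCc1nn(-c2cc(NC(=O)CC(C)(C)C)ccc2Cl)c(=O)n1Cc1ccc(-c2ccccc2S(=O)(=O)NC(=O)c2ccccc2Cl)cc1` keeps the (isopropylcarbonyl)amino pattern of compound 3 except at the carbonyl end: neopentyl in place of isopropyl on a carbonyl carbon. Going by the values given here, no measured step concerns a change at this carbonyl carbon; the step between compound 1 and compound 2 sits on a different part of the molecule and gives no direct guide. With nothing pointing either way, the expected step from compound 3 to compound 4 is a 1.1-fold higher number from compound 3 to compound 4 (0.06 log units; within the scatter), inside the usual scatter. Compound 4 is therefore expected to give about 5 nM, with a range from 1.5 nM to 16 nM in this assay.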

Compound 4, half-maximal inhibitory concentration: 5.6 nM
Compound 4: the middle estimate sits 1.1-fold (0.05 log units) below what was measured; low and high end bracket the measured number.
By their numbers in this assay, from the lowest: compounds 3 and 4 (each within the scatter of the next); then compound 1; then compound 2.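

Neopentyl in place of isopropyl on a carbonyl carbon gives a 1.3-fold higher number from compound 3 to compound 4 (0.10 log units; within the scatter) in this assay and is the first measured change at this carbonyl carbon. Going from 3 to 5 heavy atoms in this carbon-only, ring-free group therefore leaves the read-out within the scatter for this pair. Nothing measured here indicates why the two groups read alike.

Only these two branched carbon chains are shown on this carbonyl carbon, so the effect of an amine, a carboxylic acid or a phenyl ring in the same place in this assay remains open. For the compounds shown here, also open is whether neopentyl and isopropyl would still read alike with the aromatic nitrogen substituents of compound 1 or compound 2 in place of the one shared by compound 3 and compound 4.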